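The compounds below may be only part of what the source reports. "The series", "measured", "known", "first", "only" and "open" are said of these compounds alone.

Measured compounds:
compound 1 `Cc1ccc(NC(=O)C(=O)NC(c2nc(C)c(CCO)s2)C2CCCCN2)c(F)c1`, > 78800 nM in an ADME assay on TZM-b1 cells (Homo sapiens) for cytotoxicity, read by XTT assay, with a stated time of 3 days; on this read-out higher numbers stand for lower toxicity in this test and lower numbers for higher toxicity in this test.
compound 2 `Cc1nc(C(NC(=O)C(=O)Nc2ccc(Cl)c(F)c2)C2CCCCN2)sc1CCO`, 61000 nM.
compound 3 `Cc1nc(C(NC(=O)C(=O)Nc2ccc(F)c(Cl)c2)C2CCCCN2)sc1CCO`, > 75800 nM.

The values of compound 1 and compound 3 are limits of the assay, not numbers. Compound 3 therefore stands only as a limit, and the series holds one further such limit (the limit of > 78800 nM in this assay, at which 1 of the 3 values shown sits). Across the three measured compounds the changes to the aromatic group on the amide-type nitrogen left no readable step: an at least 1.2-fold lower number from compound 1 to compound 2 (0.11 log units; that floor lies within the scatter); an at least 1.2-fold higher number from compound 2 to compound 3 (0.09 log units; that floor lies within the scatter); and a step that the two limits leave unreadable from compound 1 to compound 3.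

Compound 4 `Cc1nc(C(NC(=O)C(=O)Nc2ccc(Cl)cc2)C2CCCCN2)sc1CCO` differs from compound 3 by 4-chlorophenyl in place of 3-chloro-4-fluorophenyl on an amide-type nitrogen. For the measured compounds named here, the steps that bear on this are the same ring-substituent swaps among compounds 1, 2 and 3, none of which moved beyond the scatter or past the limit. No step beyond the scatter is therefore expected in this assay, in either direction. The step that this estimate means is an at least 1.0-fold lower number from compound 3 to compound 4 (0.03 log units; that floor lies within the scatter), expected to stay within the scatter. The estimated value for compound 4 is 70000 nM, between 35000 nM and 100000 nM, with a fair chance that only a limit is reported.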

Compound 4, half-maximal cytotoxic concentration: 32800 nM
Compound 4: the middle estimate sits 2.1-fold (0.33 log units) above what was measured, and the stated range ends above it.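

In this assay, the aromatic group on the amide-type nitrogen now gives readable steps: 4-chlorophenyl yields an at least 2.3-fold lower number from compound 3 to compound 4 (0.36 log units; beyond the scatter), and an at least 2.4-fold lower number from compound 1 to compound 4 (0.38 log units; beyond the scatter), both floors set from limits of the assay. For the compounds shown here, the single change of hydrogen in place of fluoro on an aromatic carbon gives only a 1.9-fold lower number from compound 2 to compound 4 (0.27 log units; within the scatter), so compound 2 goes against any reading that compound 4 stands apart from all its neighbours. The position is therefore not silent in this test, but only the comparisons that start from a limit clear the scatter, and these move towards higher toxicity.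

On these data alone, the true sizes of those two steps stay open, and the step between compound 1 and compound 3 cannot be read. As far as these compounds go, whether unsubstituted phenyl, 4-methoxyphenyl or a 4-carboxyphenyl group on the same nitrogen would extend or break this picture also remains open.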